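Swapping a Ring for a Short Chain on the Shared Core

The source may report more compounds than this note shows. Statements on the series, on what has been measured and on what is new or still open speak of the compounds shown alone.

Compound 1, `Cc1cc(-c2ncccn2)cc(C(=O)NNS(=O)(=O)c2ccccc2)c1F`, was measured in an ADME assay on microsomes from liver (Mus musculus) for metabolic stability, read by HPLC, using NADPH, with a stated time of 60 min, tested at 1 uM, in the presence of a further agent that is not named here (a lower number here means slower removal, a higher number faster removal of the compound), where compound 1 gives 279 uL/min. Of the two numbers recorded so far this is the lower one, but the nearest neighbour, compound 2, `Cc1cc(C(=O)NNS(=O)(=O)c2ccccc2F)cc(-n2cc(F)cn2)c1`, gives 464 uL/min in this assay, and the gap between compound 1 and compound 2 lies within the usual scatter of repeated measurements, so the two cannot be ranked against each other.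

Compound 3, `C=CCOc1cc(C)c(F)c(C(=O)NNS(=O)(=O)c2ccccc2)c1`, has not yet been measured in this assay. It differs from compound 1 in one place: allyloxy in place of pyrimidin-2-yl on an aromatic carbon. Among the measured compounds shown here, no pair of measured compounds shows a step of this kind, so the two values recorded here give no direct guide to what the change will do.

For the measured compounds named here, with no comparable step in the data, the expectation for compound 3 is that its number in this assay will sit close to that of compound 1, with a shift no larger than the scatter, which means a step of a 1.3-fold higher number from compound 1 to compound 3 (0.10 log units; within the scatter). Compound 3 is therefore estimated at 350 uL/min, within a range from 170 uL/min to 750 uL/min.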

Compound 3, intrinsic clearance in a liver preparation (reported as CLH), per the amount of preparation that the assay uses: > 866 uL/min
Compound 3 gave a limit, no number; the forecaster's own chance of this, stated with the estimate: 5%; middle value at least 2.4-fold (0.39 log units) from the limit.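

Exchanging pyrimidin-2-yl for allyloxy on this aromatic carbon is the first change among these compounds with an effect that can be read clearly in this assay, as it gives an at least 3.1-fold higher number from compound 1 to compound 3 (0.49 log units; beyond the scatter). The result for compound 3 is a limit of the assay and not a number, and it is the only such result among these compounds: the limit of > 866 uL/min in this assay, at which 1 of the 3 values shown sits. The aromatic carbon para to the fluoro group is therefore not a neutral place on the shared core, since a single exchange there is enough to separate two compounds by more than the usual scatter, with compound 3 on the side of faster removal.

This single pair cannot show which part of the exchange matters, since the aromatic ring leaves while an oxygen and a double bond outside aromatic rings enter in the same step. A propoxy chain on the same carbon would keep the oxygen and drop the double bond, while an amine there would test a different kind of group, so either could help to separate these possibilities.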